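A few compounds are considered here, and "the series" means these few. Any claim that something is new, unique, unknown or untested is made for them only; others in the source may bear on it.

Measured compounds:
- compound 1 `CCNC(=O)c1cc(Oc2ccc(NC(=O)c3cc4cccnc4n(-c4ccc(Cl)cc4)c3=O)cc2)ccn1` — "not determined" (no result reported) in a functional assay on NCI-H460 cells (Homo sapiens) for antiproliferative activity, read by MTT assay, with a stated time of 72 h; a higher number here means a weaker inhibitor, a lower number a stronger inhibitor
- compound 2 `CCNC(=O)c1cc(Oc2ccc(NC(=O)c3cc4cccnc4n(-c4ccc(OC)cc4)c3=O)cc2)ccn1` — 1720 nM in this assay

Going by the values given here, compound 2 is the only compound with a number in this assay; compound 1 carries no result there, so compound 2 stands alone and cannot be ranked against anything. Compound 3 `CCNC(=O)c1cc(Oc2ccc(NC(=O)c3cc4cccnc4n(-c4ccc(Br)cc4F)c3=O)cc2)ccn1` has not yet been measured. It differs from compound 2 by 4-bromo-2-fluorophenyl in place of 4-methoxyphenyl on an aromatic nitrogen, in words 4-bromo-2-fluorophenyl in place of 4-methoxyphenyl on an aromatic nitrogen. Among the compounds with values here, no step between two measured compounds is available, so there is no measured change of this kind to set the size of this step against. The step is expected to be small, a 1.3-fold lower number from compound 2 to compound 3 (0.12 log units; within the scatter), a shift not beyond the usual scatter and with no direction that can be trusted. Compound 3 is therefore estimated at 1300 nM, with a range from 400 nM to 4500 nM.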

Compound 3, half-maximal inhibitory concentration: 1790 nM
Beside the measured number, compound 3's estimate is 1.4-fold (0.14 log units) below it; low and high end bracket the measured number.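

In this assay, the substituent on the aromatic nitrogen now has its first measured step, a 1.0-fold higher number from compound 2 to compound 3 (0.02 log units; within the scatter), so compound 2 and compound 3 cannot be told apart. This exchange replaces 4-methoxyphenyl, with its one hydrogen-bond acceptor, by 4-bromo-2-fluorophenyl, which has none, and the two compounds still read alike, so in this pair the acceptor count does not separate them. Nothing available here accounts for this similarity.

With compound 1 carrying no result, the 4-chlorophenyl group cannot be compared with either of the other two groups. Also open, from the compounds shown here alone, is whether anything other than a substituted phenyl ring at this position, such as a simple pyridine ring or a short alkyl chain like ethyl, would read differently.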